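The source may hold more compounds than are shown below. What is called first, only, known or untested is meant among the compounds shown, and "the series" means these compounds.

Compound 1 `CC(C)S(=O)(=O)c1ccccc1NCC1=NCCN1` was tested in a functional assay for agonist activity at Alpha-1A adrenergic receptor (Homo sapiens) (a lower number here means a smaller maximal response, a higher number a larger maximal response), where compound 1 reaches 70%. A second compound, compound 2 `CSc1cc(F)ccc1NCC1=NCCN1`, was measured in the same way, and in this assay compound 2 reaches 93%. On these two numbers compound 1 stands lowest: compound 2 lies higher by a gap that goes beyond the usual scatter of repeated measurements.

Compound 3 `CCS(=O)(=O)c1ccccc1NCC1=NCCN1` has not yet been measured. It differs from compound 1 in a single place: hydrogen in place of methyl on a saturated chain carbon bound to a saturated chain carbon and a sulfonyl sulfur. Taken one bond further out, this is a change from isopropylsulfonyl to ethylsulfonyl. Among the measured compounds shown here, no measured pair shows this exact change, so its effect on the maximal response is unknown. Compound 3 is estimated to keep close to compound 1, with a modest expected rise of a number 5 percentage points higher from compound 1 to compound 3 (within the scatter) in this assay. Accordingly, compound 3 is expected to reach about 75% in this assay, within a range from 55% to 95%.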

Compound 3, largest response reached (reported as maximum), in percent of the reference or control that the assay uses: 115%
Beside the measured number, compound 3's estimate is 40 percentage points below it; the whole stated range lies below it.
By their numbers in this assay, from the lowest: compound 1; then compound 2; then compound 3.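

Taking one methyl off the isopropylsulfonyl group leaves ethylsulfonyl, a loss of a single carbon, yet in this assay this gives a number 45 percentage points higher from compound 1 to compound 3 (beyond the scatter), a large step. The sulfonyl chain is therefore a place where the smallest possible trim, with the rest of the molecule unchanged, can shift the maximal response well beyond the usual scatter, which the two earlier compounds could not show because they differ in more than one place. Nothing measured here accounts for why this one carbon matters so much.

Still open, on these data alone, is whether the trend continues along this chain, meaning whether a methylsulfonyl group or a longer chain such as n-propylsulfonyl would raise or lower the response. A single step also cannot tell whether the same change would act in the same way on a core carrying a fluorine.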